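Adding a methoxy group to compound 1

The source may hold more compounds than are shown below. What is called first, only, known or untested is meant among the compounds shown, and "the series" means these compounds.

Measured in a functional assay on HL-60 cells (Homo sapiens) for cytotoxicity, read by WST assay, with a stated time of 48 h; on this read-out higher numbers stand for an effect only at larger amounts of compound and lower numbers for an effect already at smaller amounts:
compound 1 `COc1cccc(C[C@H]2C(=O)OC[C@@H]2Cc2ccccc2)c1`: 66000 nM
compound 2 `O=C1OC[C@H](Cc2ccccc2)[C@H]1Cc1cccc(Cl)c1`: 36000 nM

Within the data shown here, compound 1, at 66000 nM, lies within the scatter of compound 2, the only other compound with a number so far. Compound 3 `COc1ccc(C[C@H]2C(=O)OC[C@@H]2Cc2ccccc2)cc1OC` keeps the core of compound 1 and differs in one place: methoxy in place of hydrogen on an aromatic carbon. This is methoxy in place of hydrogen on an aromatic carbon, ortho to a methoxy group and para to a large group.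

Among the measured compounds shown here, only one measured step offers a guide, and it also changes a group on an aromatic carbon: a 1.8-fold lower number from compound 1 to compound 2 (0.26 log units; within the scatter). That step replaces a methoxy group and adds none, so it is an indirect guide. With so little evidence, no step beyond the scatter is expected in this assay, and no direction can be favoured. The expected change is a 1.2-fold lower number from compound 1 to compound 3 (0.08 log units; within the scatter). For compound 3 the estimated value is 55000 nM, with an expected range from 20000 nM to 130000 nM.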

Compound 3, half-maximal effective concentration: > 100000 nM
Compound 3: only a limit was reported (the forecaster's own chance of this, stated with the estimate: 20%); at least 1.8-fold (0.25 log units) between middle value and limit.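

In this assay, compound 3 is reported only as a limit, > 100000 nM, and not as a number. Adding a second methoxy group on the aromatic carbon ortho to a methoxy group and para to a large group gives an at least 1.5-fold higher number from compound 1 to compound 3 (0.18 log units; that floor lies within the scatter). This is the first view of a group added at this carbon, and the number did not come down with it, while the true size of the step stays unknown: the limit of > 100000 nM in this assay, at which 1 of the 3 values shown sits.

Going by these compounds, whether a hydroxy group or an amine on this same carbon would give a number that can be read stays open. A single change at this carbon also leaves open whether a chloro group here would follow the methoxy group or part from it.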